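Amide aryl group and histone deacetylase 8 inhibition

A few compounds are considered here, and "the series" means these few. Any claim that something is new, unique, unknown or untested is made for them only; others in the source may bear on it.

The three measured compounds share one core and differ only in the aryl group on the amide-type nitrogen. In an assay on isolated protein for inhibition of histone deacetylase 8 (Homo sapiens), with a stated time of 1 h (a lower number here means a stronger inhibitor, a higher number a weaker inhibitor), compound 2 `O=C(COc1ccc2cc(/C=C3/SC(=O)NC3=O)ccc2c1)Nc1ccc([N+](=O)[O-])cc1` gives 4000 nM. Compound 1 `O=C(COc1ccc2cc(/C=C3/SC(=O)NC3=O)ccc2c1)Nc1ccc(Br)cc1F` reaches only the limit of this assay, > 50000 nM. Compound 3 `O=C(COc1ccc2cc(/C=C3/SC(=O)NC3=O)ccc2c1)Nc1cc(Cl)cc(C(F)(F)F)c1` likewise sits at the limit, > 50000 nM. The step of an at least 12-fold lower number from compound 1 to compound 2 (1.09 log units; beyond the scatter) and the step of an at least 12-fold higher number from compound 2 to compound 3 (1.09 log units; beyond the scatter) are both large, while the step that the two limits leave unreadable from compound 1 to compound 3 cannot be read, as the limit of > 50000 nM in this assay, at which 2 of the 3 values shown sit, holds both ends. Compound 3 therefore stands at the weak end of the numbers shown, with only a limit to its name.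

Compound 4 `O=C(COc1ccc2cc(/C=C3/SC(=O)NC3=O)ccc2c1)Nc1ccc(Br)cc1` carries the change (4-bromophenyl in place of 3-chloro-5-(trifluoromethyl)phenyl on an amide-type nitrogen). The nearest measured guide is compound 1, whose 4-bromo-2-fluorophenyl group gave > 50000 nM, a limit; its step to compound 2 was large and was the only move away from the limit. Among the compounds with values here, no step joins a halogenated phenyl directly to 4-bromophenyl. Compound 4 is expected to stay weak, with the step of an at least 1.2-fold lower number from compound 3 to compound 4 (0.09 log units; that floor lies within the scatter) not readable from a limit. The estimate for compound 4 in this assay is 40000 nM, within 8000 nM to 200000 nM.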

Compound 4, half-maximal inhibitory concentration: 16000 nM
Beside the measured number, compound 4's estimate is 2.5-fold (0.40 log units) above it; the range from low to high includes it.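

In this assay, hydrogen in place of fluoro on an aromatic carbon gives an at least 3.1-fold lower number from compound 1 to compound 4 (0.49 log units; beyond the scatter), so this single change is enough to bring the 4-bromo series member to a readable number. 4-bromophenyl in place of 3-chloro-5-(trifluoromethyl)phenyl on the amide-type nitrogen gives an at least 3.1-fold lower number from compound 3 to compound 4 (0.49 log units; beyond the scatter), and both of these steps are floors, not measured sizes: the limit of > 50000 nM in this assay, at which 2 of the 4 values shown sit. Bromo in place of nitro on an aromatic carbon gives a 4.0-fold higher number from compound 2 to compound 4 (0.60 log units; beyond the scatter), so a readable number at this position no longer rests on the nitro group alone, although compound 2 remains the stronger of that pair.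

From the compounds shown here alone, how an amine, a carboxylic acid or a nitrile would behave in place of the bromo group of compound 4 stays open. Going by these compounds, the plain phenyl amide, with no group on the ring, also stays open.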